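Swapping Bromine for Fluorine on Two Related Cores

The source may hold more compounds than are shown below. What is called first, only, known or untested is meant among the compounds shown, and "the series" means these compounds.

Compound 1 `Sc1nnc(COc2ccc(-c3ccccc3)cc2)n1-c1ccc(Br)cc1` and compound 2 `Fc1ccc(-n2c(S)nnc2COc2ccc(-c3ccccc3)cc2)cc1` share one core, while compound 3 `Brc1ccc(Nc2nnc(COc3ccc(-c4ccccc4)cc3)s2)cc1` is built on another; the difference between the two cores is not broken down here. In a functional assay on the whole organism (strain Wistar) for inhibition, with Rattus norvegicus as the target, read by paw edema, with a stated time of 4 h, at a dose of 10 mg/kg by the oral route (a lower number here means less inhibition, a higher number more inhibition at the dose given (going by the name of the read-out)), compound 1 gives 31.8%, compound 2 gives 79.5%, and compound 3 gives 63.6%. The change from compound 1 to compound 2 is fluoro in place of bromo on an aromatic carbon, and it made the step of a number 47.7 percentage points higher from compound 1 to compound 2 (beyond the scatter). Compound 4 `Fc1ccc(Nc2nnc(COc3ccc(-c4ccccc4)cc3)s2)cc1` is not yet measured; it differs from compound 3 by fluoro in place of bromo on an aromatic carbon, the same change, which occurs twice among these compounds. Because the step of a number 47.7 percentage points higher from compound 1 to compound 2 (beyond the scatter) was large, a rise is expected from compound 3 to compound 4 in this assay, though compound 3 starts higher and less room remains, so the expected step is a number 16.4 percentage points higher from compound 3 to compound 4 (beyond the scatter). Compound 4 is therefore expected to give about 80%, between 60% and 95%.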

Compound 4, a percentage reported as inhibition, in the whole organism at one dose (the size of the read-out at that dose, not a potency): 29.5%
Compound 4: middle estimate off by 50.5 percentage points, on the high side, and the stated range ends above it.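

On the core of compound 3, fluoro in place of bromo gave a number 34.1 percentage points lower from compound 3 to compound 4 (beyond the scatter). The same change therefore does not carry over between these two cores in this assay: the same change on two cores in this assay, a number 47.7 percentage points higher (beyond the scatter) from compound 1 to compound 2 and a number 34.1 percentage points lower (beyond the scatter) from compound 3 to compound 4, 81.8 percentage points apart, beyond the scatter of two such steps. This shows that the result of this swap depends on the core that carries it, but two pairs give no rule for any further core and do not show which part of the core makes the difference.

On these data alone, it remains open whether chloro in the same place would behave like bromo or like fluoro on each core. Also open, as far as these compounds go, is how a methyl or methoxy group there would fare, and whether the order seen at this single dose would hold at other doses.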